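A few compounds are considered here, and "the series" means these few. Any claim that something is new, unique, unknown or untested is made for them only; others in the source may bear on it.

Working notes on the series, which shares one core and varies only the substituent on the amine nitrogen.

Compound 1 `O=C1C(Nc2ccccc2)=CC(=O)c2c1nc1n2[C@H]2OC[C@@H](O)[C@H]2OC1` carries an anilino group. Among the measured compounds shown here, in a functional assay on ECa-109 cells for inhibition, with ECa-109 cell line (Homo sapiens) as the target, read by sulforhodamine B assay (a higher number here means a weaker inhibitor, a lower number a stronger inhibitor), compound 1 gives 3560 nM, the only value of the set that is an actual number rather than a limit, so compound 1 is the sole fixed point on the scale. Compound 2 `O=C1C=C(NC2CCCC2)C(=O)c2c1nc1n2[C@H]2OC[C@@H](O)[C@H]2OC1` carries a cyclopentylamino group. For compound 2 this assay reports only the limit > 16000 nM, which is a limit of the assay and not a number; this is the point at which one of the two values sits (the limit of > 16000 nM in this assay, at which 1 of the 2 values shown sits).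

Compound 3 `O=C1C(NC2CCCCC2)=CC(=O)c2c1nc1n2[C@H]2OC[C@@H](O)[C@H]2OC1` is not yet measured. It differs from compound 1 by cyclohexyl in place of phenyl on an amine nitrogen. For the measured compounds named here, no step between two measured compounds with a number at each end is available, so the size of the step from compound 1 to compound 3 can only be judged from the shape of the set. The expected step of a 3.4-fold higher number from compound 1 to compound 3 (0.53 log units; beyond the scatter) points towards weaker inhibition, beyond the usual scatter, with a real chance that only a limit is reported. For compound 3 the estimated value is 12000 nM, with a range from 4000 nM to 40000 nM.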

Compound 3, half-maximal inhibitory concentration: > 16000 nM
Compound 3 ended at the assay's limit; the forecaster's own chance of this, stated with the estimate: 55%; middle value at least 1.3-fold (0.12 log units) away from the limit.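

In this assay compound 3 gives > 16000 nM, which is a limit of the assay and not a number. Cyclohexyl in place of phenyl on an amine nitrogen, with the six-membered ring of carbon kept and only its aromatic character lost, gives an at least 4.4-fold higher number from compound 1 to compound 3 (0.65 log units; beyond the scatter), the first step in the series that can be read at all, and it lies beyond the scatter. This position therefore does not tolerate every six-membered carbon ring equally, though only the lower end of the step is known and the anilino group remains the only one here with a measured number: the limit of > 16000 nM in this assay, at which 2 of the 3 values shown sit.

The compounds shown leave open whether any gain over the anilino group is possible at this nitrogen, which a chloro or methoxy substituent on the phenyl ring would begin to address. They also leave open whether the aromatic ring must sit directly on the nitrogen, a question that a benzylamino group or a pyridyl ring in place of phenyl would help to separate.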